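Methoxy added to an inducible nitric oxide synthase series

The compounds below may be only part of what the source reports. "The series", "measured", "known", "first", "only" and "open" are said of these compounds alone.

Measured compounds:
compound 1 `COc1ccc(N)c(C2=NN(C(=O)C3CCC3)CC2)c1` — 1.91%
compound 2 `Nc1ccccc1C1=NN(C(=O)CCc2ccccc2)CC1` — 5.64%

In an assay on isolated protein for inhibition of Nitric oxide synthase, inducible (Homo sapiens), with a stated time of 30 min, tested at 1 mM (a higher number here means more inhibition at the concentration tested (going by the name of the read-out), a lower number less inhibition), compound 2 stands highest of the two numbers, yet the nearest, compound 1, lies within the usual scatter of it, so the two cannot be told apart; both show little inhibition. Compound 3 `COc1ccc(N)c(C2=NN(C(=O)CCc3ccccc3)CC2)c1` differs from compound 2 by methoxy in place of hydrogen on an aromatic carbon. Going by the values given here, no measured pair carries this change alone, so no step size is known for it; in this assay no step beyond the scatter is expected, in either direction. Compound 3 is expected to give about 4.5%, within -4% to 13%. The step this estimate implies, a number 1.1 percentage points lower from compound 2 to compound 3 (within the scatter), is expected to stay within the scatter.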

Compound 3, a percentage reported as inhibition, at one concentration (the size of the read-out at that concentration, not a potency): 21.2%
Compound 3: the middle estimate sits 16.7 percentage points below what was measured; measured number outside the range, above it.
By their numbers in this assay, from the lowest: compounds 1 and 2 (each within the scatter of the next); then compound 3.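

In this assay, going by these compounds alone, methoxy on the aromatic carbon para to the amino group gives a number 15.6 percentage points higher from compound 2 to compound 3 (beyond the scatter) and so provides the first step beyond the scatter, showing that this position responds when phenethyl sits on the carbonyl. With methoxy held in place, phenethyl in place of cyclobutyl gives a number 19.3 percentage points higher from compound 1 to compound 3 (beyond the scatter) and shows that the carbonyl substituent counts as well. Nothing available bears on the cause of either step.

As far as these compounds go, whether the methoxy step holds with cyclobutyl on the carbonyl stays open. So does the outcome with ethoxy or an amine at this aromatic carbon, or with a longer chain on the carbonyl.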